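The source may report more compounds than this note shows. Statements on the series, on what has been measured and on what is new or still open speak of the compounds shown alone.

Of the compounds shown here, three have been measured in a functional assay on the whole organism (strain Fischer 344) for inhibition, with Rattus norvegicus as the target, read by paw edema, at a dose of 0.01 mmol/kg by the intraperitoneal route; on this read-out higher numbers stand for more inhibition at the one dose given (going by the name of the read-out) and lower numbers for less inhibition. Compound 1 `COC(=O)c1c(O)c2ccccc2n(-c2ccccc2)c1=O` gives 37.1%. Compound 2 `NCCNC(=O)c1c(O)c2ccccc2n(-c2ccccc2)c1=O` gives 68.1%, and the step of a number 31 percentage points higher from compound 1 to compound 2 (beyond the scatter) came with (2-aminoethyl)amino in place of methoxy on a carbonyl carbon. Compound 3 `Cn1c(=O)c(C(=O)Nc2ccccc2N)c(O)c2ccccc21` gives 85.3%, the highest of the three numbers; compound 2 stands nearest to it and compound 1 furthest, both beyond the scatter.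

Compound 4 `Nc1ccccc1NC(=O)c1c(O)c2ccccc2n(-c2ccccc2)c1=O` has not yet been measured in this assay. It differs from compound 3 by phenyl in place of methyl on an aromatic nitrogen, the change sitting on an aromatic nitrogen of the shared core. For the measured compounds named here, no measured step bears on this change: the one step known, from compound 1 to compound 2, altered the group on the carbonyl carbon while the phenyl on the nitrogen stayed fixed, so it gives no guidance on swapping methyl for phenyl there. With nothing to go on, a step near the scatter is expected, estimated as a number 11.3 percentage points lower from compound 3 to compound 4 (beyond the scatter). Compound 4 is therefore expected to give about 74%, between 50% and 93%.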

Compound 4, a percentage reported as inhibition, in the whole organism at one dose (the size of the read-out at that dose, not a potency): 48.5%
Compound 4: the middle estimate sits 25.5 percentage points above what was measured; measured number outside the range, below it.
By their numbers in this assay, from the lowest: compound 1; then compound 4; then compound 2; then compound 3.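

On the aromatic nitrogen of the shared core, phenyl in place of methyl is a costly change when the rest of the molecule stays the same in this assay (a number 36.8 percentage points lower from compound 3 to compound 4 (beyond the scatter)). With phenyl kept on that nitrogen, the group on the carbonyl carbon still matters: (2-aminophenyl)amino improves on methoxy (a number 11.4 percentage points higher from compound 1 to compound 4 (beyond the scatter)), yet 2-aminophenyl falls short of 2-aminoethyl on the amide-type nitrogen (a number 19.6 percentage points lower from compound 2 to compound 4 (beyond the scatter)), so the high number of compound 3 does not carry over to its phenyl partner. No measurement shown here accounts for these steps.

On these data alone, it remains open whether the loss is specific to phenyl or would also come with an ethyl or a benzyl group on that nitrogen. Whether methyl there would also lift the (2-aminoethyl)amino amide is equally unsettled.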